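A few compounds are considered here, and "the series" means these few. Any claim that something is new, unique, unknown or untested is made for them only; others in the source may bear on it.

Three carbamates carrying the same cyclohexylcarbamate on a phenyl ring attached to a pyrazole core have been measured. Compound 1 `CCOC(=O)c1cc(-c2cccc(OC(=O)NC3CCCCC3)c2)n(C)n1` gives 303 nM in an assay on isolated protein for inhibition of Fatty-acid amide hydrolase 1 (Homo sapiens), read by fluorescence, with a stated time of 30 min; a lower number here means a stronger inhibitor, a higher number a weaker inhibitor. Compound 2 `CC(C)NC(=O)c1cc(-c2cccc(OC(=O)NC3CCCCC3)c2)n(-c2ccccc2)n1` gives 232 nM in this assay. Compound 3 `CCOC(=O)c1cc(-c2ccc(OC(=O)NC3CCCCC3)cc2)nn1-c1ccccc1` gives 592 nM in this assay, the highest of the three numbers; the nearest is compound 1, a gap that lies within the scatter, and the furthest is compound 2, a gap beyond the scatter. No pair among these three differs in one place only, so no single step is available from the measured set.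

Compound 4 `CCOC(=O)c1cc(-c2ccc(OC(=O)NC3CCCCC3)cc2)nn1-c1ccc(OC)cc1` is the next member, not yet measured. It differs from compound 3 by methoxy in place of hydrogen on an aromatic carbon, on the phenyl that sits on the nitrogen of the core. Going by the values given here, nothing among the measured compounds shows how this substitution pattern behaves, and the change is small in size. The step from compound 3 to compound 4 is therefore expected to be a 1.1-fold lower number from compound 3 to compound 4 (0.06 log units; within the scatter) in this assay, that is, nothing beyond the scatter in either direction. Compound 4 is expected to give 520 nM in this assay, between 200 nM and 1400 nM.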

Compound 4, half-maximal inhibitory concentration: 159 nM
Beside the measured number, compound 4's estimate is 3.3-fold (0.51 log units) above it, and the stated range ends above it.
By their numbers in this assay, from the lowest: compounds 4, 2, 1 and 3 (each within the scatter of the next, the first and the last beyond it).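

Going by these compounds alone, the change from phenyl to 4-methoxyphenyl is the first single change readable, and in this assay it gives a 3.7-fold lower number from compound 3 to compound 4 (0.57 log units; beyond the scatter). Methoxy placed on an aromatic carbon para to a large group therefore lowers the number beyond the scatter, so this position is not indifferent to substitution, though this rests on one pair alone. No measurement at hand accounts for the size or direction of this step.

Going by these compounds, whether the lower number is particular to methoxy remains open, as a hydroxyl, a chlorine, a dimethylamino group or a longer ether such as ethoxy at the same place could behave differently. On these data alone, it is also open whether methoxy has the same effect on the phenyl of compound 2, which carries an isopropyl amide in place of the ethyl ester.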